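Swapping one aryl group on compound 1

A few compounds are considered here, and "the series" means these few. Any claim that something is new, unique, unknown or untested is made for them only; others in the source may bear on it.

Compound 1, `O=C(/C(=C\c1ccc(Br)c(O)c1)Sc1ccc(Br)cc1)c1ccc(Br)cc1`, is the starting point. In a functional assay on DU-145 cells (Homo sapiens) for inhibition, read by trypan blue exclusion, with a stated time of 96 h (on this read-out higher numbers stand for weaker inhibition of growth and lower numbers for stronger inhibition of growth), compound 1 gives 1000 nM. Compound 2, `O=C(O)c1ccc(C(=O)/C(=C\c2ccc(Cl)c([N+](=O)[O-])c2)SCc2ccc(F)cc2)cc1`, which has different substituents, gives 1000 nM in this assay, so the two stand level within the usual scatter. Compound 3, `Cc1ccc(S(=O)(=O)/C(=C/c2ccc(N(C)C)cc2)C(=O)c2ccc(Cl)cc2)cc1`, returned only a limit of the assay, > 100000 nM. Compound 1 therefore sits level with compound 2, while the remaining compound offers no number for comparison. Within the data shown here, no two measured compounds differ in just one place, so no measured step shows what a single change does here.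

Compound 4, `COc1ccc(/C=C(/Sc2ccc(Br)cc2)C(=O)c2ccc(Br)cc2)c(F)c1`, keeps the rest of compound 1 and changes one group: 2-fluoro-4-methoxyphenyl in place of 4-bromo-3-hydroxyphenyl on a double-bonded chain carbon bound to a double-bonded chain carbon. It carries 2-fluoro-4-methoxyphenyl in place of 4-bromo-3-hydroxyphenyl on a double-bonded chain carbon bound to a double-bonded chain carbon. Among the measured compounds shown here, with no measured precedent for this exchange, the expectation in this assay is a small shift toward weaker growth inhibition, one that may not exceed the scatter, and it is anchored on compound 1 at 1000 nM. The expected step is a 2.0-fold higher number from compound 1 to compound 4 (0.30 log units; within the scatter). Compound 4 is estimated at about 2000 nM. The expected range for compound 4 runs from 300 nM to 15000 nM.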

Compound 4, concentration for 50% growth inhibition: 20000 nM
The estimate for compound 4 lay 10-fold (1.00 log units) below the measured number, outside the stated range (above it).
By their numbers in this assay, from the lowest: compounds 1 and 2 (each within the scatter of the next); then compound 4. At a limit, above all of these: compound 3.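

Among these compounds, the exchange of 2-fluoro-4-methoxyphenyl for 4-bromo-3-hydroxyphenyl on a double-bonded chain carbon bound to a double-bonded chain carbon gives the first single-place comparison in this set: a 20-fold higher number from compound 1 to compound 4 (1.30 log units; beyond the scatter). In this assay, among the compounds shown here, growth inhibition therefore depends on which aryl group sits at this place, something the earlier compounds, which differ in more than one place, could not show. The exchange alters several things together, including the loss of the hydrogen-bond donor counted on the leaving group, the replacement of bromine by fluorine and the gain of one heavy atom, and nothing measured here ties the step to any one of these features.

The compounds shown leave open whether the hydroxy group, the bromine, the fluorine or the methoxy group accounts for the step, as no compound shown changes only one of them. They also leave open how a phenyl group carrying a nitrile or a trifluoromethyl group would stand at this place in this assay.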